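Swapping the Piperidine Substituent of a Weak GIPR Agonist

The compounds below may be only part of what the source reports. "The series", "measured", "known", "first", "only" and "open" are said of these compounds alone.

Compound 1 `CC(=O)c1cnc(N2CCC(c3coc4c(N5CCc6cc(S(C)(=O)=O)ccc65)ncnc34)CC2)nc1` gives 12% in a functional assay on cells for agonist activity at Glucose-dependent insulinotropic receptor (Homo sapiens), read by a luciferase reporter, with a stated time of 4 h (a lower number here means a smaller maximal response, a higher number a larger maximal response), the lowest of the two numbers at hand, while compound 2 `CC(C)(C)OC(=O)N1CCC(c2coc3c(Nc4ccc(S(C)(=O)=O)cc4F)ncnc23)CC1` gives 123% in the same assay. Compound 3 `CC(C)(C)OC(=O)N1CCC(c2coc3c(N4CCc5cc(S(C)(=O)=O)ccc54)ncnc23)CC1` has not yet been measured. It differs from compound 1 in one place: tert-butoxycarbonyl in place of 5-acetylpyrimidin-2-yl on an amine nitrogen in a ring. Among the compounds with values here, no step between measured compounds with exactly this change exists, so the direction rests only on compound 2, whose value 123% also carries the tert-butoxycarbonyl group. A large upward step, well beyond the scatter, is expected, a number 53 percentage points higher from compound 1 to compound 3 (beyond the scatter). Compound 3 is estimated at 65%, within 20% to 115%.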

Compound 3, largest response reached (Emax), in percent of the reference or control that the assay uses: 123%
Beside the measured number, compound 3's estimate is 58 percentage points below it; the measured number lies above the stated range.
By their numbers in this assay, from the lowest: compound 1; then compounds 2 and 3 (each within the scatter of the next).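

On an otherwise unchanged core, tert-butoxycarbonyl in place of 5-acetylpyrimidin-2-yl on an amine nitrogen in a ring brings, in this assay, a number 111 percentage points higher from compound 1 to compound 3 (beyond the scatter). This single position can therefore decide the size of the maximal response, which compound 2, differing from compound 1 in more than this group, could not show. Nothing at hand explains the step. As far as these compounds go, it remains open whether ethoxycarbonyl or an unsubstituted pyrimidin-2-yl on this nitrogen would give a response nearer that of compound 3 or that of compound 1.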